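This account rests on a few compounds, and the source may have more. Where it says the series, first, only, none or still open, it means among the compounds named here.

Compound 1 `CNc1nc(N)nc2c1ncn2/C=C1/CC1(CO)CO` gives > 20000 nM in an ADME assay on MOLT-3 cells (Homo sapiens) for cytotoxicity, with a stated time of 7 days (a lower number here means that less compound is tolerated, a higher number that more compound is tolerated), which is a limit of the assay rather than a number.
Compound 2 `Nc1nc(N2CCCC2)c2ncn(/C=C3/CC3(CO)CO)c2n1` gives "not determined" (no result reported) in this assay.
Compound 3 `CCCCCCCCSc1nc(N)nc2c1ncn2/C=C1/CC1(CO)CO` gives > 20000 nM in this assay, again a limit of the assay rather than a number.

Compound 3 therefore stands at the top edge of what was measured: no cytotoxicity was found up to the highest concentration tested. Compound 1 sits at the same limit, and for compound 2 no result was obtained. For the measured compounds named here, the one step between measured compounds, a step that the two limits leave unreadable from compound 1 to compound 3, cannot be read, because both ends rest on (the limit of > 20000 nM in this assay, at which 2 of the 3 values shown sit).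

Compound 4 `CCCCSc1nc(N)nc2c1ncn2/C=C1/CC1(CO)CO` differs from compound 3 by hydrogen in place of butyl on a saturated chain carbon, four bonds along the chain from a sulfur, so the chain on the sulfur is shortened while the rest of the shared core is kept. Going by the values given here, no measured step bears directly on this change, and the only readable neighbours, compound 1 and compound 3, both sit at the limit. The expectation is therefore that compound 4 also shows no cytotoxicity within the tested range, with a step that the limit leaves unreadable from compound 3 to compound 4 that is expected to lie within the scatter. Compound 4 is estimated at 30000 nM in this assay, with a range from 12000 nM to 100000 nM.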

Compound 4, half-maximal cytotoxic concentration: > 20000 nM
Compound 4 was reported as a limit; the forecaster's own chance of this, stated with the estimate: 80%; the middle value lies beyond the limit too.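

No step can be read from compound 4 to its neighbours, compound 3 and compound 1, because each pair rests on the same limit rather than on numbers: the limit of > 20000 nM in this assay, at which 3 of the 4 values shown sit.

The compounds shown leave open at what concentration, if any, compound 1, compound 3 and compound 4 harm these cells, and whether the length of the chain on the sulfur matters.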